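Trading Nitro for Trifluoromethyl on a Shared Core

This account rests on a few compounds, and the source may have more. Where it says the series, first, only, none or still open, it means among the compounds named here.

Of the compounds shown here, three built on one core have been tested in a functional assay on A549 cells (Homo sapiens) for inhibition, read by MTT assay, with a stated time of 24 h; a lower number here means a stronger inhibitor, a higher number a weaker inhibitor. Compound 1 `CCOC(=O)C1=Cc2ccccc2OC1(OCc1cc(-c2ccc(C)cc2)no1)C(F)(F)F` carries a methylphenyl group; in this assay compound 1 reaches only > 150000 nM, which is a limit of the assay rather than a number. Compound 2 `CCOC(=O)C1=Cc2ccccc2OC1(OCc1cc(-c2ccc(Cl)cc2)no1)C(F)(F)F` carries a chlorophenyl group and gives 19100 nM, the lowest number of the three. Compound 3 `CCOC(=O)C1=Cc2ccccc2OC1(OCc1cc(-c2ccc([N+](=O)[O-])cc2)no1)C(F)(F)F` carries a nitrophenyl group; in this assay compound 3 also stops at > 150000 nM, again a limit rather than a number. Compound 3 therefore stands with compound 1 at the weak end of the set (the limit of > 150000 nM in this assay, at which 2 of the 3 values shown sit).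

Compound 4 `CCOC(=O)C1=Cc2ccccc2OC1(OCc1cc(-c2cccc(C(F)(F)F)c2)no1)C(F)(F)F` is not yet measured. It differs from compound 3 by 3-(trifluoromethyl)phenyl in place of 4-nitrophenyl on an aromatic carbon. Within the data shown here, two measured steps touch this kind of exchange: an at least 7.8-fold lower number from compound 1 to compound 2 (0.89 log units; beyond the scatter) and an at least 7.8-fold higher number from compound 2 to compound 3 (0.89 log units; beyond the scatter). The step that the two limits leave unreadable from compound 1 to compound 3 cannot be read. Both readable steps are large, so swapping this group can move the number well beyond the scatter in either direction, the chloro group giving the lowest number and the nitro group the limit. Compound 4 with its trifluoromethyl group is expected to land between these, estimated at 60000 nM (range 10000 nM to 400000 nM). That estimate means an expected step of an at least 2.5-fold lower number from compound 3 to compound 4 (0.39 log units; beyond the scatter), though with compound 3 at a limit it remains only an expectation.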

Compound 4, half-maximal inhibitory concentration: 48600 nM
Compound 4: middle estimate off by 1.2-fold (0.09 log units), on the high side; low and high end bracket the measured number.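

Until now, only the 4-chlorophenyl group of compound 2 had given a real number in this assay. The groups of compound 1 and compound 3 had stopped at a limit of the assay. The 3-(trifluoromethyl)phenyl group shows that a second group at this place on the shared core can also give a number, with an at least 3.0-fold lower number from compound 3 to compound 4 (0.48 log units; beyond the scatter) and an at least 3.0-fold lower number from compound 1 to compound 4 (0.48 log units; beyond the scatter). It does not match the 4-chlorophenyl group, however, with a 2.5-fold higher number from compound 2 to compound 4 (0.41 log units; beyond the scatter), which leaves compound 2 with the lowest number of the set. Compound 1 and compound 3 remain at a limit of the assay, so their true values are unknown: the limit of > 150000 nM in this assay, at which 2 of the 4 values shown sit.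

Compound 4 differs from the others both in the group on the phenyl ring and in where that group sits, so these compounds cannot show which of the two changes matters. On these data alone, how an amine, a carboxylic acid or a methoxy group on that phenyl ring would read also remains open.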